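Removing the bromoacrylamide from the chalcone amine

A few compounds are considered here, and "the series" means these few. Any claim that something is new, unique, unknown or untested is made for them only; others in the source may bear on it.

The set is built around three measured chalcone-type compounds. Compound 1 `C=C(Br)C(=O)Nc1ccc(/C=C/C(=O)c2ccc(OCC)cc2)cc1` carries a (1-bromoethenyl)carbonyl on the aromatic nitrogen, and in a functional assay on FM3A cells (Mus musculus) for antiproliferative activity, with a stated time of 48 h (on this read-out higher numbers stand for weaker inhibition and lower numbers for stronger inhibition), compound 1 gives 680 nM. Compound 2 `C=C(Br)C(=O)Nc1ccc(C(=O)/C=C/c2ccccc2)cc1` keeps that group but differs from compound 1 in its core; how the two cores differ is not broken down here. In this assay compound 2 gives 690 nM, within the scatter of compound 1. Compound 3 `CCOc1ccc(C(=O)/C=C/c2ccc(N)cc2)cc1` is the parent amine of compound 1, the change being (hydrogen in place of (1-bromoethenyl)carbonyl on a nitrogen on an aromatic ring); in this assay compound 3 gives 55000 nM, and the step is an 81-fold higher number from compound 1 to compound 3 (1.91 log units; beyond the scatter).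

Compound 4 `Nc1ccc(C(=O)/C=C/c2ccccc2)cc1` is the corresponding parent amine of compound 2, the change being (hydrogen in place of (1-bromoethenyl)carbonyl on a nitrogen on an aromatic ring), at a place described in the same words as before, so it is the same change. Among the measured compounds shown here, because the one measured instance of this change gave an 81-fold higher number from compound 1 to compound 3 (1.91 log units; beyond the scatter), the step from compound 2 to compound 4 is expected to be of similar size, an 80-fold higher number from compound 2 to compound 4 (1.90 log units; beyond the scatter). Compound 4 is therefore estimated at 55000 nM, with an expected range from 18000 nM to 160000 nM.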

Compound 4, half-maximal inhibitory concentration: 34000 nM
For compound 4 the middle estimate is 1.6-fold (0.21 log units) above the measured one, and the stated range covers the measured number.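

In this assay, replacing ((1-bromoethenyl)carbonyl)amino with amino gives a 49-fold higher number from compound 2 to compound 4 (1.69 log units; beyond the scatter), and set beside the earlier step, the change carries over between the two cores: the same change on two cores in this assay, an 81-fold higher number (1.91 log units; beyond the scatter) from compound 1 to compound 3 and a 49-fold higher number (1.69 log units; beyond the scatter) from compound 2 to compound 4, 1.6-fold (0.22 log units) apart, within the scatter of two such steps. On both cores shown, then, the amide bearing the (1-bromoethenyl)carbonyl gives a much lower number than its parent amine, and the size of that step does not measurably depend on which of these two cores carries it. Among the compounds shown here, this rests on only two pairs in a single assay, so it does not show that the step would keep its size on other cores, nor does it show why the group matters or which of its parts is responsible.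

The compounds shown leave open whether the bromine itself is needed, as a plain acryloyl or an acetyl group on the same nitrogen would test. They also leave open how the step behaves on a core carrying a further group, such as a carboxylic acid or a longer alkoxy chain.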